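Ring contraction on the side chain of compound 1

The source may report more compounds than this note shows. Statements on the series, on what has been measured and on what is new or still open speak of the compounds shown alone.

In a functional assay on A549 cells (Homo sapiens) for antiproliferative activity, read by MTT assay, with a stated time of 72 h (a higher number here means a weaker inhibitor, a lower number a stronger inhibitor), compound 1 `COc1cc2ncnc(Nc3ccc(Br)cc3F)c2cc1OCCCN1CCNCCNCCNCC1` gives 15200 nM and compound 3 `COc1cc2ncnc(Nc3cccc(I)c3)c2cc1OCCCN1CCNCCNCCNCC1` gives 14500 nM, values within the scatter of each other. Compound 2 `COc1cc2ncnc(Nc3cccc(F)c3)c2cc1OCCCN1CCNCCNCCNCC1` gives > 50000 nM, which is a limit of the assay.

Compound 4 `COc1cc2ncnc(Nc3ccc(Br)cc3F)c2cc1OCCCN1CCNCCNCC1` departs from compound 1 in one place: a group of 9 heavy atoms (6 carbon, 3 nitrogen; one nine-membered non-aromatic ring with 3 hetero atoms) in place of a group of 12 heavy atoms (8 carbon, 4 nitrogen; one twelve-membered non-aromatic ring with 4 hetero atoms), on a saturated chain carbon, three bonds along the chain from an oxygen on an aromatic ring. The measured steps, an at least 3.2-fold higher number from compound 1 to compound 2 (0.51 log units; beyond the scatter), a 1.0-fold lower number from compound 1 to compound 3 (0.02 log units; within the scatter) and an at least 3.4-fold lower number from compound 2 to compound 3 (0.53 log units; beyond the scatter), all change only the group on a nitrogen on an aromatic ring, so none of them tests the ring change. For the measured compounds named here, with no measured step on this ring, the expectation stays at compound 1, at 15200 nM, with no step beyond the scatter expected in this assay. The expected step is a 1.0-fold lower number from compound 1 to compound 4 (0.01 log units; within the scatter). The estimate for compound 4 is 15000 nM, with an expected range of 6000 nM to 40000 nM.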

Compound 4, half-maximal inhibitory concentration: 16100 nM
Compound 4: the middle estimate sits 1.1-fold (0.03 log units) below what was measured; low and high end bracket the measured number.
By their numbers in this assay, from the lowest: compounds 3, 1 and 4 (each within the scatter of the next). At a limit, above all of these: compound 2.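

The first test of the ring on the saturated chain carbon, with the 4-bromo-2-fluorophenyl group held fixed, gives a 1.1-fold higher number from compound 1 to compound 4 (0.02 log units; within the scatter) in this assay. The earlier steps shown here changed only the group on a nitrogen on an aromatic ring, whereas this one shows that the ring of compound 1 can give way to the nine-membered ring without a step beyond the scatter. No measurement shown here accounts for this result.

On these data alone, it remains open whether a piperazine or a morpholine at this place would fall within the same scatter. As far as these compounds go, the same ring change also remains open with the 3-iodophenyl group.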